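Shortening and stripping the amide side chain in compound 4

This account rests on a few compounds, and the source may have more. Where it says the series, first, only, none or still open, it means among the compounds named here.

Of the compounds shown here, three sharing one core have been measured in an assay on HL-60 cells for agonist activity at vitamin D3 receptor (Homo sapiens), read by microscopy, with a stated time of 96 h; on this read-out higher numbers stand for an effect only at larger amounts of compound and lower numbers for an effect already at smaller amounts. Compound 1 `CC[C@@H](C)[C@H](NC(=O)c1ccc(C(CC)(CC)c2ccc(OCC(O)C(C)(C)C)c(C)c2)n1CC)C(=O)OC` gives 26 nM, compound 2 `CCN(CC)CCNC(=O)c1ccc(C(CC)(CC)c2ccc(OCC(O)C(C)(C)C)c(C)c2)n1CC` gives 110 nM, and compound 3 `CCN(CC)CCCNC(=O)c1ccc(C(CC)(CC)c2ccc(OCC(O)C(C)(C)C)c(C)c2)n1CC` gives 66 nM. Compound 3 therefore holds the second highest of the three numbers: its nearest neighbour is compound 2, separated by a 1.7-fold lower number from compound 2 to compound 3 (0.22 log units; within the scatter), while compound 1 lies further off, by a 2.5-fold higher number from compound 1 to compound 3 (0.40 log units; beyond the scatter).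

Compound 4 `CCn1c(C(=O)NCCN)ccc1C(CC)(CC)c1ccc(OCC(O)C(C)(C)C)c(C)c1` is not yet measured. It differs from compound 3 by amino in place of (diethylamino)methyl on a saturated chain carbon, two bonds along the chain from an amide-type nitrogen. Two of the measured steps speak to how this assay responds to changes on the amide side chain. The steps of a 4.2-fold higher number from compound 1 to compound 2 (0.63 log units; beyond the scatter) and a 2.5-fold higher number from compound 1 to compound 3 (0.40 log units; beyond the scatter) show that replacing the branched ester-bearing chain by a diethylamino-bearing chain raises the number to a modest degree. The step of a 1.7-fold lower number from compound 2 to compound 3 (0.22 log units; within the scatter) shows that moving the diethylamino group one carbon further along the chain changes the number within the scatter only.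

Since the change toward compound 4 removes the diethyl groups and shortens the chain at once, a modest rise beyond the scatter is expected, in the direction seen in a 4.2-fold higher number from compound 1 to compound 2 (0.63 log units; beyond the scatter). Compound 4 is therefore estimated at 150 nM, within a range from 50 nM to 450 nM, which corresponds to an expected step of a 2.3-fold higher number from compound 3 to compound 4 (0.36 log units; beyond the scatter).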

Compound 4, half-maximal effective concentration: 10 nM
Compound 4: middle estimate off by 15-fold (1.18 log units), on the high side; the whole stated range lies above it.
By their numbers in this assay, from the lowest: compound 4; then compound 1; then compounds 3 and 2 (each within the scatter of the next).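

Going by these compounds alone, removing the diethyl substitution while keeping the chain length, amino in place of diethylamino, gives an 11-fold lower number from compound 2 to compound 4 (1.04 log units; beyond the scatter) in this assay, so this end of the side chain can shift the number much further than the earlier compounds showed. The change from 3-(diethylamino)propyl to 2-aminoethyl, which shortens the chain as well, gives a 6.6-fold lower number from compound 3 to compound 4 (0.82 log units; beyond the scatter), whereas the earlier change in chain length stayed within the scatter. The comparison with the branched ester-bearing group also reverses: 2-aminoethyl gives a 2.6-fold lower number from compound 1 to compound 4 (0.41 log units; beyond the scatter), while both diethylamino-bearing chains gave higher numbers than compound 1, so replacing that group does not always raise the number, and compound 4 now has the lowest number of the set.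

The data shown give no measured reason for this drop. The compounds shown also leave open whether 3-aminopropyl would keep the low number, which would separate the effect of chain length from that of the diethyl substitution, and whether a single ethyl on the amine, as in 2-(ethylamino)ethyl, would fall nearer compound 2 or compound 4.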